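Thiazolylidene hydrazides: chloro to methyl on the aryl ring

This account rests on a few compounds, and the source may have more. Where it says the series, first, only, none or still open, it means among the compounds named here.

Three compounds in this series share one core and differ in the aryl substituent and in the sulfur-linked heterocycle. Compound 1 `Cc1ccc(-c2cs/c(=N/NC(=O)CSc3nnnn3C)n2-c2ccccc2)cc1` bears a 4-methylphenyl group; in a functional assay on C6 cells (Rattus norvegicus) for cytotoxicity, read by MTT assay, with a stated time of 24 h, tested at 200 ug/mL (a lower number here means a stronger effect, a higher number a weaker effect of the compound at the concentration tested), compound 1 gives 39.7%. Compound 2 `O=C(CSc1ncccn1)N/N=c1/scc(-c2ccc(Br)cc2)n1-c1ccccc1` bears a bromo group on the aryl ring and in this assay compound 2 gives 63.2%. Compound 3 `O=C(CSc1ncccn1)N/N=c1/scc(-c2ccc(Cl)cc2)n1-c1ccccc1` carries chloro in the same position and in this assay compound 3 gives 39.7%. Compound 3 thus stands level with compound 1 at the digits given, the two together being the lowest of the three numbers, and the step of a number 23.5 percentage points lower from compound 2 to compound 3 (beyond the scatter) is beyond the scatter.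

Compound 4 `Cc1ccc(-c2cs/c(=N/NC(=O)CSc3ncccn3)n2-c2ccccc2)cc1` is the next member. The difference from compound 3 is methyl in place of chloro on an aromatic carbon.

Within the data shown here, no measured step covers a chloro to methyl exchange. Among the measured compounds shown here, the one step, a number 23.5 percentage points lower from compound 2 to compound 3 (beyond the scatter), concerns two halogens and does not bear directly on this change. Compound 1, which carries 4-methylphenyl but differs elsewhere, sits at the same value as compound 3. On this basis the step of a number 2.3 percentage points higher from compound 3 to compound 4 (within the scatter) is expected to stay within the scatter. Compound 4 is therefore estimated at 42% in this assay, with a range from 28% to 60%.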

Compound 4, a percentage reported as activity, at one concentration (the size of the read-out at that concentration, not a potency): 43.7%
The estimate for compound 4 lay 1.7 percentage points below the measured number; the measured number falls inside the stated range.
By their numbers in this assay, from the lowest: compounds 1, 3 and 4 (each within the scatter of the next); then compound 2.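

On the aryl ring, with pyrimidin-2-yl held on the sulfur, this assay shows a number 4 percentage points higher from compound 3 to compound 4 (within the scatter) for the change from 4-chlorophenyl to 4-methylphenyl, so the methyl and chloro compounds are not separated at this position. The same position gives a number 19.5 percentage points lower from compound 2 to compound 4 (beyond the scatter) for methyl in place of bromo, which places compound 2 apart from compound 4 as well as from compound 3 and makes bromo the only one of these three substituents that stands apart in this pyrimidin-2-yl subset. Among these compounds, the first reading on the sulfur side, with 4-methylphenyl held, is a number 4 percentage points higher from compound 1 to compound 4 (within the scatter) for pyrimidin-2-yl in place of 1-methyl-1H-tetrazol-5-yl, so these two heterocycles are not separated here.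

No supporting measurement is available to explain why bromo stands apart from chloro and methyl. Still open, as far as these compounds go, are how a methoxy group, an amine or a carboxylic acid would read at this aryl position, and whether the bromo result would carry over with 1-methyl-1H-tetrazol-5-yl on the sulfur.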